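The compounds below may be only part of what the source reports. "The series", "measured", "known", "first", "only" and "open" are said of these compounds alone.

Measured in a functional assay on MCF7 cells (Homo sapiens) for inhibition, read by crystal violet staining, with a stated time of 4 days; on this read-out higher numbers stand for weaker inhibition and lower numbers for stronger inhibition:
- compound 1 `CN(C)S(=O)(=O)c1ccc2c(c1)/C(=C1/Nc3ccccc3/C1=N\O)C(=O)N2`: 400 nM
- compound 2 `CN(C)CCN(C)S(=O)(=O)c1ccc2c(c1)/C(=C1/Nc3ccccc3/C1=N\O)C(=O)N2`: < 100 nM, a limit of the assay
- compound 3 `C=CCC1(O)/C(=C2/C(=O)Nc3ccc(S(=O)(=O)N(C)C)cc32)Nc2ccccc21`: 200 nM

Compound 3 at 200 nM and compound 1 at 400 nM lie within the scatter of each other. Compound 4 `C=CCC1(O)/C(=C2/C(=O)Nc3ccc(S(=O)(=O)N(C)CCN(C)C)cc32)Nc2ccccc21` differs from compound 3 as follows: (dimethylamino)methyl in place of hydrogen on a saturated chain carbon bound to a sulfonamide nitrogen. This places (dimethylamino)methyl in place of hydrogen on a saturated chain carbon bound to a sulfonamide nitrogen. Among the measured compounds shown here, one measured step bears on this, the same change, seen as an at least 4.0-fold lower number from compound 1 to compound 2 (0.60 log units; beyond the scatter), which lies beyond the scatter. A lower number of similar size is therefore expected in this assay. The expected step is a 4.0-fold lower number from compound 3 to compound 4 (0.60 log units; beyond the scatter). Compound 4 is estimated at 50 nM, with an expected range of 20 nM to 130 nM.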

Compound 4, half-maximal inhibitory concentration in the MCF7 assay: < 100 nM
Compound 4 ended at the assay's limit; the forecaster's own chance of this, stated with the estimate: 55%; the middle value is on the limit's open side.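

On a second core, in the MCF7 assay, the same change gives an at least 2.0-fold lower number from compound 3 to compound 4 (0.30 log units; that floor lies within the scatter), so the lower number seen on the first core recurs, though this floor alone does not clear the scatter. The two cores agree in direction, but their sizes cannot be compared: the same change on two cores in the MCF7 assay, an at least 4.0-fold lower number (0.60 log units; beyond the scatter) from compound 1 to compound 2 and an at least 2.0-fold lower number (0.30 log units; that floor lies within the scatter) from compound 3 to compound 4; the limit leaves it open whether they differ In a physicochemical assay for solubility, in phosphate buffer, measured as kinetic solubility, at pH 7.4 (a higher number here means a more soluble compound, a lower number a less soluble compound), compound 3 gives 31 ug/mL as its value. In the physicochemical assay compound 4 gives > 40 ug/mL as a limit of the assay. In the physicochemical assay the step reads an at least 1.2-fold higher number from compound 3 to compound 4 (0.11 log units; that floor lies within the scatter), and this too is only a floor: the limit of > 40 ug/mL in the physicochemical assay, at which 1 of the 2 values shown sits.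

On these data alone, the true size of the change stays open in both assays. As far as these compounds go, it also remains open whether a longer chain or a carboxylic acid in place of 2-(dimethylamino)ethyl would give a similar step.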